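Methoxy for hydroxy on a 3-chloro-5-hydroxyphenyl series

This account rests on a few compounds, and the source may have more. Where it says the series, first, only, none or still open, it means among the compounds named here.

Measured so far:
compound 1 `O=C(Nc1cccc(-n2cc(-c3ccncc3)c(-c3cc(O)cc(Cl)c3)n2)c1)Nc1ccc(Cl)c(Cl)c1`: -56.5%
compound 2 `COc1cc(Cl)cc(-c2nn(-c3cccc(NC(=O)Nc4ccc(Cl)c(Cl)c4)c3)cc2-c2ccncc2)c1`: 3.01%
compound 3 `O=C(Nc1cccc(-n2cc(-c3ccncc3)c(-c3cc(O)cc(Cl)c3)n2)c1)c1cc(C(F)(F)F)cc(C(F)(F)F)c1`: 37.2%

In a functional assay on U-251 cells (Homo sapiens) for inhibition, read by sulforhodamine B assay, with a stated time of 48 h, tested at 10 uM (on this read-out lower numbers stand for a stronger effect and higher numbers for a weaker effect at the one concentration tested), compound 1 gives -56.5%, the lowest of the three numbers. Compound 2 differs from compound 1 only by methyl in place of hydrogen on an oxygen on an aromatic ring, and the measured step is a number 59.5 percentage points higher from compound 1 to compound 2 (beyond the scatter). In this assay compound 3 gives 37.2%, the highest of the three; compound 1 and compound 3 differ in the group carried on the amide side, and the difference between the two cores is not broken down here.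

Compound 4 `COc1cc(Cl)cc(-c2nn(-c3cccc(NC(=O)c4cc(C(F)(F)F)cc(C(F)(F)F)c4)c3)cc2-c2ccncc2)c1` has not yet been measured. Going by the values given here, it differs from compound 3 by methyl in place of hydrogen on an oxygen on an aromatic ring, which is the same change as the one from compound 1 to compound 2. The place of the change reads the same in both pairs. Given that this change gave a number 59.5 percentage points higher from compound 1 to compound 2 (beyond the scatter), a shift of the same sign is expected for compound 4, estimated as a number 40.8 percentage points higher from compound 3 to compound 4 (beyond the scatter). The size is set somewhat smaller than the earlier step, since compound 3 already starts from 37.2% and the read-out cannot go far past the level of no effect. Compound 4 is thus expected to give about 78% in this assay, most likely between 50% and 105%.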

Compound 4, a percentage reported as activity, at one concentration (the size of the read-out at that concentration, not a potency): 60.7%
Compound 4: middle estimate off by 17.3 percentage points, on the high side; low and high end bracket the measured number.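

In this assay, hydroxy to methoxy on the 3-chloro-5-hydroxyphenyl group again raises the number, a number 23.5 percentage points higher from compound 3 to compound 4 (beyond the scatter), so the direction of the step, towards a weaker effect at the one concentration tested, is the same on both cores. The size of the step does not carry over from one core to the other: the same change on two cores in this assay, a number 59.5 percentage points higher (beyond the scatter) from compound 1 to compound 2 and a number 23.5 percentage points higher (beyond the scatter) from compound 3 to compound 4, 36 percentage points apart, beyond the scatter of two such steps. Two pairs show a shared direction on these two cores only; they give no size that could be applied to a further core, and they do not show which feature of the cores goes with the larger or the smaller step.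

Going by these compounds, it remains open whether the rise follows from the methyl on the oxygen as such or from the loss of the hydrogen, a question that a longer chain on the same oxygen, such as ethyl, or an amine in place of the hydroxy could help to address. Also open, on these data alone, is whether the same direction would hold on a third core, for example one carrying a carboxylic acid on the ring at the far end of the amide, and whether the gap between the two steps would persist in other cell lines.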